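The source may report more compounds than this note shows. Statements on the series, on what has been measured and on what is new or still open speak of the compounds shown alone.

Working notes on the group at the aromatic nitrogen, read in a functional assay on TSGH cells (Homo sapiens) for inhibition, with a stated time of 72 h; on this read-out lower numbers stand for stronger inhibition and higher numbers for weaker inhibition. Compound 1 (`CCn1ccc2cc(C(=O)c3cc(OC)c(OC)c(OC)c3)ccc21`) gives 41 nM, and compound 2 (`COc1cc(C(=O)c2ccc3c(ccn3C(C)C)c2)cc(OC)c1OC`), which carries isopropyl, gives 1100 nM. Compound 3 (`COc1cc(C(=O)c2ccc3c(ccn3CO)c2)cc(OC)c1OC`), which carries hydroxymethyl, gives 43 nM, which places it level with compound 1 and far under compound 2.

Compound 4 (`COc1cc(C(=O)c2ccc3c(ccn3CC(=O)O)c2)cc(OC)c1OC`) has carboxy in place of hydroxy on a saturated chain carbon bound to an aromatic nitrogen. The same change reads hydroxymethyl to carboxymethyl.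

Within the data shown here, three measured steps bear on this carbon. Hydroxy in place of methyl gave a 1.0-fold higher number from compound 1 to compound 3 (0.02 log units; within the scatter), so that swap was silent. Methyl in place of hydrogen gave a 27-fold higher number from compound 1 to compound 2 (1.43 log units; beyond the scatter), and hydroxymethyl in place of isopropyl gave a 26-fold lower number from compound 2 to compound 3 (1.41 log units; beyond the scatter), both large. Among the measured compounds shown here, no measured compound carries a carboxy group, so the read-across is indirect. For the measured compounds named here, the closest precedent is the one measured enlargement of the group, with a 27-fold higher number from compound 1 to compound 2 (1.43 log units; beyond the scatter), and it points to weaker inhibition.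

A large move towards higher numbers is therefore expected in this assay, with the estimated step being a 35-fold higher number from compound 3 to compound 4 (1.54 log units; beyond the scatter). The estimate for compound 4 is 1500 nM, with an expected range of 200 nM to 10000 nM.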

Compound 4, half-maximal inhibitory concentration: 548 nM
The estimate for compound 4 lay 2.7-fold (0.44 log units) above the measured number; measured number inside the range.
By their numbers in this assay, from the lowest: compounds 1 and 3 (each within the scatter of the next); then compounds 4 and 2 (each within the scatter of the next).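

In this assay, the saturated chain carbon bound to the aromatic nitrogen proves sensitive to the group it carries, even without the branching seen in compound 2: carboxy in place of hydroxy gives a large step (a 13-fold higher number from compound 3 to compound 4 (1.11 log units; beyond the scatter)). Carboxy in place of methyl gives a step of similar printed size (a 13-fold higher number from compound 1 to compound 4 (1.13 log units; beyond the scatter)), so the silent exchange of methyl for hydroxy between compound 1 and compound 3 does not extend to every group at this carbon. Carboxymethyl in place of isopropyl on the aromatic nitrogen stays within the scatter (a 2.0-fold lower number from compound 2 to compound 4 (0.30 log units; within the scatter)), so two structurally different groups, one branched and one carrying carboxy, land at a similar level, well apart from compound 1 and compound 3.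

Whether the step belongs to the carboxylic acid itself remains open, since the methyl ester, the primary amide and a longer chain ending in a carboxylic acid are absent from the compounds shown. An amine on the same carbon would also test how far this carbon tolerates other groups, and no data shown here give a reason for the step at this position.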